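A few compounds are considered here, and "the series" means these few. Any claim that something is new, unique, unknown or untested is made for them only; others in the source may bear on it.

Compounds measured so far in a functional assay on MT2 cells (Homo sapiens) for cytotoxicity, read by MTT assay; a higher number here means that more compound is tolerated, a lower number that less compound is tolerated:

compound 1, `Clc1ccc(Nc2nnc(Cc3ccccc3)o2)cc1` — compound 1 gives 31000 nM
compound 2, `Clc1ccc(Nc2nnc(Cc3c(Cl)cccc3Cl)o2)cc1Cl` — compound 2 reaches only the assay limit, > 100000 nM
compound 3, `CC(C)=CCOc1cc(NC(=S)c2ccoc2C)ccc1Cl` — compound 3 gives 41000 nM

Where compound 2 stands, then, is not a number but a limit: of the three values shown, it is the one sitting at the limit of > 100000 nM in this assay, at which 1 of the 3 values shown sits, so the cells tolerated it up to the highest concentration tested. Compound 1 and compound 3 both return numbers that lie close to each other and somewhat below that limit, but nothing connects compound 2 to either of them by a single change, so their values say only what they show.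

The next compound, compound 4, `FC(F)(F)c1cc(Nc2nnc(Cc3c(Cl)cccc3Cl)o2)ccc1Cl`, grows out of compound 2 by one change: trifluoromethyl in place of chloro on an aromatic carbon. Among the compounds with values here, no pair of measured compounds differing in just one place is available to gauge what such a swap does in this assay, so the expected step can rest only on where compound 2 stands. Compound 4 is therefore expected to remain in the same, well-tolerated region, with a step from compound 2 of an at least 1.2-fold lower number from compound 2 to compound 4 (0.09 log units; that floor lies within the scatter) that may amount to no more than the scatter. The estimate for compound 4 in this assay is 80000 nM, within a range from 25000 nM to 300000 nM, and it is quite possible that the assay will again report only a limit.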

Compound 4, half-maximal cytotoxic concentration: 9000 nM
For compound 4 the middle estimate is 8.9-fold (0.95 log units) above the measured one; measured number below the stated range.
By their numbers in this assay, from the lowest: compound 4; then compounds 1 and 3 (each within the scatter of the next). At a limit, above all of these: compound 2.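

In this assay compound 2 stands at a limit and not at a number: the limit of > 100000 nM in this assay, at which 1 of the 4 values shown sits.

On an aromatic carbon ortho to a chloro group and meta to a large group, trifluoromethyl in place of chloro gives an at least 11-fold lower number from compound 2 to compound 4 (1.04 log units; beyond the scatter), a large step and the first in this set to link two measured compounds by a single change. The earlier compounds shown here could show only where each one stood, whereas this pair shows that what sits at this position matters for how much compound the cells tolerate, and the true size of the step may be greater still, as it starts from a limit.

With this single step, what it is about the swap that matters stays open, and the compounds shown say nothing about whether the drop depends on trifluoromethyl itself or would appear with other groups. As far as these compounds go, how a methoxy, a nitrile or an amine on the same aromatic carbon would fare remains open, as does whether the same swap would lower the number on a different core.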